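Chain shortening on the bis(trifluoromethyl) anilide

A few compounds are considered here, and "the series" means these few. Any claim that something is new, unique, unknown or untested is made for them only; others in the source may bear on it.

Measured compounds:
compound 1, `CCCCCCCCC(=O)N1c2ccccc2CCC1C(=O)Nc1ccccc1C(F)(F)F` — 6180 nM
compound 2, `CCC(=O)N1c2ccccc2CCC1C(=O)Nc1ccccc1C(F)(F)F` — > 80000 nM
compound 3, `CCCCCCCCC(=O)N1c2ccccc2CCC1C(=O)Nc1cc(C(F)(F)F)cc(C(F)(F)F)c1` — 2230 nM

In a functional assay on NUGC-3 cells (Homo sapiens) for cytotoxicity, read by sulforhodamine B assay, with a stated time of 72 h (on this read-out higher numbers stand for weaker inhibition of growth and lower numbers for stronger inhibition of growth), compound 1 gives 6180 nM. Compound 2 reaches only a limit of the assay, > 80000 nM, which is the limit of > 80000 nM in this assay, at which 1 of the 3 values shown sits. Compound 3 gives 2230 nM, the lowest of the two numbers given.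

The change from compound 1 to compound 2 is hydrogen in place of hexyl on a saturated chain carbon, two bonds along the chain from a carbonyl carbon and gave an at least 12-fold higher number from compound 1 to compound 2 (1.11 log units; beyond the scatter). Compound 4, `CCC(=O)N1c2ccccc2CCC1C(=O)Nc1cc(C(F)(F)F)cc(C(F)(F)F)c1`, is not yet measured; it differs from compound 3 by hydrogen in place of hexyl on a saturated chain carbon, two bonds along the chain from a carbonyl carbon, the same change made on the same place. The difference between the two cores of compound 1 and compound 3 is not broken down here.

For compound 4 a step of about an 18-fold higher number from compound 3 to compound 4 (1.25 log units; beyond the scatter) in this assay is expected, resting on the large loss seen as an at least 12-fold higher number from compound 1 to compound 2 (1.11 log units; beyond the scatter), applied to the starting point of compound 3 at 2230 nM. Compound 4 is therefore estimated at 40000 nM, with a real chance that only a limit is reported.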

Compound 4, concentration for 50% growth inhibition: 7220 nM
Compound 4: the middle estimate sits 5.5-fold (0.74 log units) above what was measured; measured number outside the range, below it.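

In this assay, hydrogen in place of hexyl on the core of compound 3 gives a 3.2-fold higher number from compound 3 to compound 4 (0.51 log units; beyond the scatter), so the direction of the change carries over from the core of compound 1 but its size does not: the same change on two cores in this assay, an at least 12-fold higher number (1.11 log units; beyond the scatter) from compound 1 to compound 2 and a 3.2-fold higher number (0.51 log units; beyond the scatter) from compound 3 to compound 4, at least 3.9-fold (0.60 log units) apart, beyond the scatter of two such steps

Going by these compounds, compound 2 stands at > 80000 nM, which is a limit of the assay and not a number, so the full size of the step to it and of the gap between the two steps stays unknown. These two pairs show that the same change can cost different amounts on different cores; they do not show why, or how it would behave on any further core.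

Only propanoyl and octylcarbonyl appear on these two cores, which leaves open how the read-out runs for chains of intermediate length. Also open, on these data alone, is whether a longer chain, or a chain ending in an amine or a carboxylic acid, would go beyond compound 3 on the same core.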